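Urea-piperazine dithiocarbamate triazoles: ethyl to cyclohexyl urea

This account rests on a few compounds, and the source may have more. Where it says the series, first, only, none or still open, it means among the compounds named here.

Measured so far in a functional assay on MGC-803 cells (Homo sapiens) for cytotoxicity, read by MTT assay, with a stated time of 72 h; a higher number here means a weaker inhibitor, a lower number a stronger inhibitor:
compound 1, `CCNC(=O)N1CCN(C(=S)SCc2cn(Cc3ccccc3F)nn2)CC1` — compound 1 gives 2830 nM
compound 2, `CCNC(=O)N1CCN(C(=S)SCc2cn(Cc3ccc(F)cc3)nn2)CC1` — compound 2 gives 2170 nM

Within the data shown here, only two compounds carry numbers. Among the measured compounds shown here, compound 2 stands with compound 1 inside the usual scatter: a 1.3-fold lower number from compound 1 to compound 2 (0.12 log units; within the scatter), the one measured step, concerns the fluorine on the benzyl ring and not the urea end of the molecule. For the measured compounds named here, no measured pair differs at the amide-type nitrogen.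

The next compound is compound 3, `O=C(NC1CCCCC1)N1CCN(C(=S)SCc2cn(Cc3ccc(F)cc3)nn2)CC1`. Relative to compound 2 the change is cyclohexyl in place of ethyl on an amide-type nitrogen. Going by the values given here, nothing measured in this assay bears on that part of the structure, so there is no step from which to read a direction or a size. The working expectation is therefore no step beyond the scatter, with a wide band in either direction: the estimated step is a 1.1-fold lower number from compound 2 to compound 3 (0.04 log units; within the scatter). On that basis compound 3 is expected to give about 2000 nM in this assay, with a range from 600 nM to 7000 nM.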

Compound 3, half-maximal inhibitory concentration: > 128000 nM
Compound 3: a limit, no number; the forecaster's own chance of this, stated with the estimate: 5%; middle value at least 64-fold (1.80 log units) from the limit.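

Among these compounds, the urea end of the molecule, which no earlier pair touched, is the first place where a single change moves the read-out in this assay beyond the scatter: cyclohexyl in place of ethyl on an amide-type nitrogen gives an at least 58-fold higher number from compound 2 to compound 3 (1.77 log units; beyond the scatter), a large step, whereas the only earlier step, a 1.3-fold lower number from compound 1 to compound 2 (0.12 log units; within the scatter), concerned the fluorine on the benzyl ring and stayed within the scatter. The value for compound 3 is a limit of the assay and not a number: the limit of > 128000 nM in this assay, at which 1 of the 3 values shown sits. The step therefore fixes a direction and a minimum size, and it rests on one pair with the 4-fluorophenyl group held constant, so it shows that this position is sensitive to this change but gives no general trend with the size of the group.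

The compounds shown leave open whether the step goes with the ring itself or with the number of carbons, which an open butyl or hexyl chain and a smaller cyclopropyl ring on the same nitrogen could separate. They also leave open whether cyclohexyl has the same outcome with the 2-fluorophenyl group of compound 1.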